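Methoxy addition on a triazole series: cytotoxicity working notes

The source may hold more compounds than are shown below. What is called first, only, known or untested is meant among the compounds shown, and "the series" means these compounds.

Measured so far:
Compound 1 `COc1ccc(-n2cc(-c3ccc(OC)c(OC)c3)nn2)cc1`: in a functional assay on MDA-MB-231 cells (Homo sapiens) for cytotoxicity, read by MTT assay (on this read-out lower numbers stand for stronger inhibition and higher numbers for weaker inhibition), compound 1 gives > 100 nM, a limit of the assay rather than a number.
Compound 2 `COc1ccc(-c2cn(-c3ccc(OC)cc3)nn2)cc1`: in this assay compound 2 gives > 100 nM, likewise a limit.
Compound 3 `COc1ccc(-n2cc(-c3cc(O)cc(O)c3)nn2)cc1`: in this assay compound 3 gives > 10000 nM, again only a limit.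

The change methoxy in place of hydrogen on an aromatic carbon is made between the two measured compounds, and its step that the two limits leave unreadable from compound 2 to compound 1 cannot be read because of the limit of > 100 nM in this assay, at which 2 of the 3 values shown sit. Compound 3 stands only at a limit because of the limit of > 10000 nM in this assay, at which 1 of the 3 values shown sits. How the core of compound 3 differs from that of compound 2 is not broken down here.

Compound 4 `COc1ccc(-n2cc(-c3cc(O)cc(O)c3)nn2)cc1OC` carries the same change, (methoxy in place of hydrogen on an aromatic carbon), on the core of compound 3; the place of the entering methoxy is described in the same words for both pairs, so it is taken as the same change.

Since compound 3 shows only a limit in this assay and the only measured instance of this change is itself unreadable, nothing shown points to a gain; the step that the limit leaves unreadable from compound 3 to compound 4 is therefore expected to be small, and a further limit is the likelier outcome. Compound 4 is estimated at 20000 nM, with a plausible range from 5000 nM to 100000 nM.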

Compound 4, half-maximal inhibitory concentration: > 10000 nM
Compound 4: only a limit was reported; the forecaster's own chance of this, stated with the estimate: 75%; the middle value does not contradict the limit.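

In this assay compound 4 gives > 10000 nM, a limit and not a number. No step can be read from compound 3 to compound 4, because both stand only at a limit: the limit of > 10000 nM in this assay, at which 2 of the 4 values shown sit.

The compounds shown leave open whether methoxy in place of hydrogen on an aromatic carbon changes cytotoxicity at all, on either the core of compound 2 or that of compound 3.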